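This account rests on a few compounds, and the source may have more. Where it says the series, first, only, none or still open, it means among the compounds named here.

Among the compounds with values here, in a physicochemical assay for solubility, read by mass spectrometry, in phosphate buffer, with a stated time of 24 h, at pH 7.4 (a higher number here means a more soluble compound, a lower number a less soluble compound), compound 2 `Cc1occc1C(=O)N1CCC(NC(=O)Nc2ccc(C(F)(F)F)cc2)CC1` gives 0.28 ug/mL, the lowest of the three numbers so far, against compound 1 `O=C(Nc1ccc(C(F)(F)F)cc1)NC1CCN(C(=O)C2CCCOC2)CC1` at 1.1 ug/mL and compound 3 `Cc1occc1C(=O)N1CCC(NC(=O)Nc2ccc(OC(F)(F)F)cc2)CC1` at 8.6 ug/mL. Compound 4 `Cc1ccoc1C(=O)N1CCC(NC(=O)Nc2ccc(C(F)(F)F)cc2)CC1` has the same atoms, joined differently: 3-methylfuran-2-yl in place of 2-methylfuran-3-yl on a carbonyl carbon, with 3-methylfuran-2-yl in place of 2-methylfuran-3-yl on a carbonyl carbon. The measured steps bear on this only indirectly. The modest 3.9-fold lower number from compound 1 to compound 2 (0.59 log units; beyond the scatter) occurred at this place but involved oxan-3-yl, while the large 31-fold higher number from compound 2 to compound 3 (1.49 log units; beyond the scatter) occurred on an aromatic carbon. Within the data shown here, no measured step exchanges one methylfuran group for another, so no step beyond the scatter is expected in this assay. The expected step is a 1.4-fold higher number from compound 2 to compound 4 (0.15 log units; within the scatter). Compound 4 is estimated at 0.4 ug/mL, within an expected range of 0.12 ug/mL to 1.5 ug/mL.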

Compound 4, solubility: 0.8 ug/mL
Estimate against measurement, compound 4: 2.0-fold (0.30 log units) below; low and high end bracket the measured number.
By their numbers in this assay, from the lowest: compound 2; then compounds 4 and 1 (each within the scatter of the next); then compound 3.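

In this assay the exchange of 2-methylfuran-3-yl for 3-methylfuran-2-yl on this carbonyl carbon gives a 2.9-fold higher number from compound 2 to compound 4 (0.46 log units; beyond the scatter) with the atoms unchanged, so the way the methylfuran is joined matters at this place. The exchange of oxan-3-yl for 3-methylfuran-2-yl gives a 1.4-fold lower number from compound 1 to compound 4 (0.14 log units; within the scatter) and so, unlike the step to compound 2, stays within the scatter. Nothing measured here accounts for the gap between the two methylfuran groups. Going by these compounds, whether trifluoromethoxy in place of trifluoromethyl would act on compound 4 as it did on compound 2 remains open, as does the outcome with an amine or a carboxylic acid on the methylfuran.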